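From 4-hydroxyphenyl to 3,4-dihydroxyphenyl on the shared core

This account rests on a few compounds, and the source may have more. Where it says the series, first, only, none or still open, it means among the compounds named here.

In a functional assay on HeLa cells (Homo sapiens) for inhibition, read by sulforhodamine B assay, with a stated time of 72 h (on this read-out higher numbers stand for weaker inhibition and lower numbers for stronger inhibition), compound 1 (`C[C@H](OC(=O)/C=C\c1ccc(O)cc1)[C@@H]1CC[C@H]([C@H](O)[C@H]2CC=CC(=O)O2)O1`) gives 3300 nM and compound 2 (`C[C@H](OC(=O)/C=C/c1ccc(O)cc1)[C@@H]1CC[C@H]([C@H](O)[C@H]2CC=CC(=O)O2)O1`) gives the higher number of the two (9500 nM). Going by the values given here, the only measured step is a 2.9-fold higher number from compound 1 to compound 2 (0.46 log units; beyond the scatter) and it comes with the fact that compounds 1 and 2 differ only in the configuration as drawn as its sole structural difference, a double bond drawn Z in one and E in the other. Compound 3 (`C[C@H](OC(=O)/C=C/c1ccc(O)c(O)c1)[C@@H]1CC[C@H]([C@H](O)[C@H]2CC=CC(=O)O2)O1`) keeps the E double bond of compound 2 and carries hydroxy in place of hydrogen on an aromatic carbon as its change, hydroxy in place of hydrogen on an aromatic carbon, ortho to a hydroxy group. Among the compounds with values here, no measured step touches this position, so the direction is open. With a 2.9-fold higher number from compound 1 to compound 2 (0.46 log units; beyond the scatter) as the only yardstick, a move no larger than that is expected, leaning weakly toward a lower number. The estimated change is a 1.5-fold lower number from compound 2 to compound 3 (0.16 log units; within the scatter) and remains loosely held. For compound 3 the expected value is 6500 nM (estimated range 2200 nM to 19000 nM).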

Compound 3, half-maximal inhibitory concentration: 6900 nM
The estimate for compound 3 lay 1.1-fold (0.03 log units) below the measured number; the measured number falls inside the stated range.
By their numbers in this assay, from the lowest: compound 1; then compounds 3 and 2 (each within the scatter of the next).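

In this assay, going by these compounds alone, the first measured step on the aromatic ring is a 1.4-fold lower number from compound 2 to compound 3 (0.14 log units; within the scatter) and it shows that, with the E double bond in place, hydroxy in place of hydrogen ortho to a hydroxy group leaves the number within the scatter. Going from 4-hydroxyphenyl to 3,4-dihydroxyphenyl therefore gives no readable gain or loss at this position, whereas the only earlier step concerned the double bond configuration. Nothing available bears on why this added hydroxy leaves the number within the scatter.

Open, as far as these compounds go, is whether a methoxy group, an amine or a fluorine atom at this same place would move the number beyond the scatter. Also open, from the compounds shown here alone, is how 3,4-dihydroxyphenyl reads on the Z double bond of compound 1.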